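The source may report more compounds than this note shows. Statements on the series, on what has been measured and on what is new or still open speak of the compounds shown alone.

Measured values in an ADME assay on MT4 cells (Homo sapiens) for activation, read by MTT assay; a lower number here means that less compound is tolerated, a higher number that more compound is tolerated:

compound 1, `CCC(C)Sc1nc(Cc2c(F)cccc2Cl)cc(=O)[nH]1`: > 76000 nM; this value is a limit of the assay.
compound 2, `CCCCSc1nc(Cc2c(F)cccc2Cl)cc(=O)[nH]1`: > 76000 nM; this value is a limit of the assay.
compound 3, `CCC(C)Sc1nc(C(C)c2c(F)cccc2Cl)c(C)c(=O)[nH]1`: > 1500 nM; this value is a limit of the assay.

Compound 1 and compound 2 share a core and differ by butyl in place of sec-butyl on a sulfur. The step that the two limits leave unreadable from compound 1 to compound 2 cannot be read because both values sit at the limit of > 76000 nM in this assay, at which 2 of the 3 values shown sit. Compound 3 differs from compound 1 in more than one place; the difference between the two cores is not broken down here. Compound 4, `CCCCSc1nc(C(C)c2c(F)cccc2Cl)c(C)c(=O)[nH]1`, not yet measured in this assay, differs from compound 3 by butyl in place of sec-butyl on a sulfur, the same change as from compound 1 to compound 2, on the same kind of sulfur. Since that change left no readable step, the expected step that the limit leaves unreadable from compound 3 to compound 4 is set near zero and rests on compound 3 sitting at the limit of > 1500 nM in this assay, at which 1 of the 3 values shown sits. In this assay compound 4 is expected at 20000 nM, with a range from 1500 nM to 100000 nM, and a limit rather than a number is the likely outcome.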

Compound 4, half-maximal cytotoxic concentration: > 1500 nM
Compound 4: no number, only a limit (the forecaster's own chance of this, stated with the estimate: 75%); the middle value does not contradict the limit.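

In this assay, no step can be read from compound 3 to compound 4, because the values of both compounds are the same limit of the assay, not numbers: the limit of > 1500 nM in this assay, at which 2 of the 4 values shown sit.

The compounds shown leave open whether butyl in place of sec-butyl on a sulfur changes this read-out on either core.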